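From Isopropyl to Propyl on the Nitrogen

This account rests on a few compounds, and the source may have more. Where it says the series, first, only, none or still open, it means among the compounds named here.

Measured in a functional assay on Chorioallantoic membrane (Gallus gallus, strain Leghorn), read by microscopy, with a stated time of 40 h; a lower number here means a stronger inhibitor, a higher number a weaker inhibitor:
Compound 1 `COc1ccc(Nc2ncnc3occ(C)c23)cc1`: 445 nM
Compound 2 `COc1ccc(N(c2ncnc3occ(C)c23)C(C)C)cc1`: 480 nM

For the measured compounds named here, compound 2 gives 480 nM, which lies within the scatter of the only other measured value, so neither compound ranks ahead. Compound 3 `CCCN(c1ccc(OC)cc1)c1ncnc2occ(C)c12` has the same atoms as compound 2, joined differently, with propyl in place of isopropyl on a nitrogen on an aromatic ring. Going by the values given here, no measured compound carries propyl, so the change has not been tested directly. Among the compounds with values here, the one measured step that bears on it puts isopropyl in place of hydrogen on that nitrogen and gives a 1.1-fold higher number from compound 1 to compound 2 (0.03 log units; within the scatter). Given that small step, the exchange of isopropyl for propyl is expected to produce no change beyond the scatter in this assay, and no direction is favoured. The estimated step is a 1.0-fold lower number from compound 2 to compound 3 (0.02 log units; within the scatter). The expected value for compound 3 is 460 nM, with an estimated range from 200 nM to 1000 nM.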

Compound 3, half-maximal inhibitory concentration: 301 nM
The estimate for compound 3 lay 1.5-fold (0.18 log units) above the measured number, within the range that was stated.
By their numbers in this assay, from the lowest: compounds 3, 1 and 2 (each within the scatter of the next).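

The earlier compounds had shown only hydrogen and isopropyl on this nitrogen on an aromatic ring; the result adds propyl, which has the same atoms as isopropyl, joined differently. In this assay the exchange of isopropyl for propyl gives a 1.6-fold lower number from compound 2 to compound 3 (0.20 log units; within the scatter), and propyl in place of hydrogen gives a 1.5-fold lower number from compound 1 to compound 3 (0.17 log units; within the scatter), so neither step separates the compounds. Hydrogen, isopropyl and propyl at this position therefore all stand within the scatter of one another in this assay, and the way the chain is joined shows no effect beyond it.

The compounds shown leave open whether a longer chain such as butyl, or a chain ending in an amine or a carboxylic acid, would move the number beyond the scatter. Nothing at hand explains these numbers.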